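The compounds below may be only part of what the source reports. "The series", "measured", "known", "first", "only" and "open" are said of these compounds alone.

Compound 1 `N#Cc1c(Cl)nc(SCC(=O)Nn2c(COc3ccc(Cl)cc3Cl)nc3ccccc3c2=O)nc1-c1ccccc1` gives 68.4% in a functional assay on the whole organism (strain albino) for inhibition, with Rattus norvegicus as the target, read by paw edema, with stated times of 1 h and 3 h, at a dose of 100 mg/kg by the oral route; on this read-out lower numbers stand for a weaker effect and higher numbers for a stronger effect at the one dose given. Compound 2 `N#Cc1c(Cl)nc(SCC(=O)Nn2c(COc3ccc(Cl)cc3Cl)nc3ccccc3c2=O)nc1-c1ccc(Cl)cc1` gives 68.4%, and compound 3 `N#Cc1c(Cl)nc(SCC(=O)Nn2c(COc3ccc(Cl)cc3Cl)nc3ccccc3c2=O)nc1-c1ccc(O)cc1` gives 73.7%. Compound 3 thus holds the highest of the three numbers, though the steps of a number 5.3 percentage points higher from compound 1 to compound 3 (within the scatter) and a number 5.3 percentage points higher from compound 2 to compound 3 (within the scatter) both stay within the scatter, as does no change at the digits printed from compound 1 to compound 2 (within the scatter). Compound 4 `N#Cc1c(Nc2ccccc2)nc(SCC(=O)Nn2c(COc3ccc(Cl)cc3Cl)nc3ccccc3c2=O)nc1-c1ccc(O)cc1` differs from compound 3 by anilino in place of chloro on an aromatic carbon. Within the data shown here, no measured step touches this position: all three concern the hydroxy or chloro exchanges on the other aromatic ring, and none of them moved the read-out beyond the scatter. With nothing bearing on the change and the whole series flat, the step expected for compound 4 is a number 3.7 percentage points lower from compound 3 to compound 4 (within the scatter), none beyond the scatter. Compound 4 is therefore estimated at 70%, with a range from 55% to 85%.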

Compound 4, a percentage reported as inhibition, in the whole organism at one dose (the size of the read-out at that dose, not a potency): 91.2%
Compound 4: the middle estimate sits 21.2 percentage points below what was measured; measured number outside the range, above it.
By their numbers in this assay, from the lowest: compounds 1, 2 and 3 (each within the scatter of the next); then compound 4.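

Anilino in place of chloro on the carbon next to the ring nitrogen and ortho to a cyano group gives a number 17.5 percentage points higher from compound 3 to compound 4 (beyond the scatter) in this assay. Among these compounds, it is the only step beyond the scatter, so this position responds where the exchanges on the other aromatic ring did not. No measurement available bears on why the step arises.

Open, on these data alone, is whether the gain needs the aromatic ring of anilino or only its nitrogen, which methylamino or morpholine at this carbon would separate. Open too, as far as these compounds go, is whether the step holds with phenyl or 4-chlorophenyl in place of the 4-hydroxyphenyl group.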